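Isopropyl in Place of a Two-Ring Group on the Sulfonyl

The compounds below may be only part of what the source reports. "The series", "measured", "known", "first", "only" and "open" are said of these compounds alone.

Of the compounds shown here, three have been measured in an ADME assay on the whole organism (blood, Mus musculus, strain C57BL/6) for pharmacokinetics, read by HPLC, with a stated time of 4 h, at a dose of 2 mg/kg by the intraperitoneal route; on this read-out lower numbers stand for lower exposure and higher numbers for higher exposure at the dose given. Compound 1 `CN1CCN(S(=O)(=O)c2c(Cl)ccc(NC(=O)Nc3cccc(Cl)c3Cl)c2O)CC1` gives 303 ng.h/mL, compound 2 `CCS(=O)(=O)c1c(Cl)ccc(NC(=O)Nc2cccc(Cl)c2Cl)c1O` gives 256 ng.h/mL, and compound 3 `CN1CC2(CC(S(=O)(=O)c3c(Cl)ccc(NC(=O)Nc4cccc(F)c4Cl)c3O)C2)C1` gives 1050 ng.h/mL. Compound 3 stands highest of the three numbers, beyond the scatter above both compound 1 and compound 2.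

Compound 4 `CC(C)S(=O)(=O)c1c(Cl)ccc(NC(=O)Nc2cccc(F)c2Cl)c1O` differs from compound 3 in one place: a group of 3 heavy atoms (3 carbon; no ring) in place of a group of 8 heavy atoms (7 carbon, 1 nitrogen; one four-membered non-aromatic ring of carbon only, one four-membered non-aromatic ring with 1 hetero atom), on a sulfonyl sulfur.

Among the measured compounds shown here, the one measured step of a similar kind is a 1.2-fold lower number from compound 1 to compound 2 (0.07 log units; within the scatter), in which ethyl replaced 4-methylpiperazin-1-yl on the sulfonyl sulfur, and that step lay within the scatter. On that basis a small downward step or none beyond the scatter is expected from compound 3 to compound 4 in this assay, though the group leaving here is larger than in that earlier step and compound 3 and compound 1 also differ elsewhere, so the comparison is loose. Compound 4 is therefore estimated at 700 ng.h/mL, with a range from 300 ng.h/mL to 1500 ng.h/mL, meaning an expected step of a 1.5-fold lower number from compound 3 to compound 4 (0.18 log units; within the scatter).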

Compound 4, area under the concentration-time curve: 198 ng.h/mL
For compound 4 the middle estimate is 3.5-fold (0.55 log units) above the measured one; the measured number lies below the stated range.
By their numbers in this assay, from the lowest: compounds 4, 2 and 1 (each within the scatter of the next); then compound 3.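

In this assay the group on the sulfonyl sulfur can move the number beyond the scatter: isopropyl in place of the two-ring group gives a 5.3-fold lower number from compound 3 to compound 4 (0.72 log units; beyond the scatter) on the same core. The earlier change to ethyl from 4-methylpiperazin-1-yl, by contrast, gave a 1.2-fold lower number from compound 1 to compound 2 (0.07 log units; within the scatter) and stayed within the scatter, so these two steps show that this position is not indifferent to every change and that the outcome depends on the groups exchanged. No measurement available here accounts for the size of the new step.

Which part of the two-ring group goes with the higher number remains open, and a single-ring 1-methylazetidin-3-yl group on the sulfonyl sulfur would bear on that. Also open, going by these compounds, is how 4-methylpiperazin-1-yl and the two-ring group would compare on one core.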